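Swapping chloro for acetoxy on a cytotoxic dienone

The compounds below may be only part of what the source reports. "The series", "measured", "known", "first", "only" and "open" are said of these compounds alone.

Measured in a functional assay on HGC-27 cells (Homo sapiens) for cytotoxicity, read by MTT assay, with a stated time of 72 h; a lower number here means a stronger inhibitor, a higher number a weaker inhibitor:
Compound 1 `O=C1C=CCC/C1=C\C(Br)=C\c1ccccc1` gives > 10000 nM
Compound 2 `O=C1C=CCC/C1=C\C=C\c1ccc(Cl)cc1` gives 4800 nM
Compound 3 `O=C1C=CCC/C1=C\C=C\c1ccccc1[N+](=O)[O-]` gives 4400 nM

Compound 1 gives > 10000 nM as a limit of the assay, not as a number. That leaves two real numbers to compare. Compound 2 stands at 4800 nM and compound 3 stands at 4400 nM in this assay, and these two values lie within the usual scatter of repeated measurements. Neither can be ranked over the other.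

The next compound to be tested is compound 4 `CC(=O)Oc1ccc(/C=C/C=C2\CCC=CC2=O)cc1`. It is compound 2 with acetoxy in place of chloro on an aromatic carbon, para to a large group (acetoxy in place of chloro on an aromatic carbon). Among the compounds with values here, no measured pair here differs in one place only, so no direct step can serve as a guide. Compound 2 and compound 3 do carry different groups on the aromatic ring, yet their values show no gap beyond the scatter. On that limited basis, no step beyond the scatter is expected in this assay, in either direction. The estimated step is a 1.0-fold higher number from compound 2 to compound 4 (0.02 log units; within the scatter), which is small. For compound 4 the expected value is 5000 nM, with an estimated range of 2000 nM to 12000 nM.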

Compound 4, half-maximal inhibitory concentration: 4900 nM
For compound 4 the middle estimate is 1.0-fold (0.01 log units) above the measured one; the range from low to high includes it.
By their numbers in this assay, from the lowest: compounds 3, 2 and 4 (each within the scatter of the next). At a limit, above all of these: compound 1.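

Within the data shown here, this is the first pair of compounds here that differ in one place only, so it gives the first direct reading of a change on the aromatic ring: in this assay, the swap of chloro for acetoxy gives a 1.0-fold higher number from compound 2 to compound 4 (0.01 log units; within the scatter). The swap is not a small one on paper, since a single chlorine atom leaves and a group of 4 heavy atoms enters, bringing 2 hydrogen-bond acceptors and a double bond where chloro had none. Even so, on this aromatic carbon, para to a large group, the two compounds cannot be told apart in this cytotoxicity reading, so this one position accepts at least this one larger group with no step beyond the scatter.

Going by these compounds, whether that holds for other kinds of group at the same place, such as an amine, a carboxylic acid or a longer chain, stays open, as one swap cannot show how far the tolerance reaches. Compound 1 is held at a limit rather than a number, so it gives no step to set beside this one: the limit of > 10000 nM in this assay, at which 1 of the 4 values shown sits.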